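Acetyl to Methylsulfonyl on the Ring Oxygen

This account rests on a few compounds, and the source may have more. Where it says the series, first, only, none or still open, it means among the compounds named here.

Measured compounds:
compound 1 `OC1C[C@@H]2CCCC[C@@H]2[C@H]1/C=C/c1ccc(-c2cccc(F)c2)cn1` — 220 nM
compound 2 `CC(=O)OC1C[C@@H]2CCCC[C@@H]2[C@H]1/C=C/c1ccc(-c2cccc(F)c2)cn1` — 67 nM

Of the compounds shown here, two sharing one core have been measured in an assay on cell membranes for displacement of a labelled ligand from proteinase-activated receptor 1 (Homo sapiens), read by scintillation counting, with a stated time of 60 min; a higher number here means a weaker inhibitor, a lower number a stronger inhibitor. Compound 1 gives 220 nM, and compound 2, which carries an acetyl on the oxygen instead of hydrogen, gives 67 nM. The step is a 3.3-fold lower number from compound 1 to compound 2 (0.52 log units; beyond the scatter). Among the compounds with values here, compound 2 therefore holds the lower of the two numbers, with compound 1 as its only neighbour.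

Compound 3 `CS(=O)(=O)OC1C[C@@H]2CCCC[C@@H]2[C@H]1/C=C/c1ccc(-c2cccc(F)c2)cn1` is the next member. It differs from compound 2 by methylsulfonyl in place of acetyl on an oxygen on a saturated carbon. Within the data shown here, only one measured step touches this oxygen, a 3.3-fold lower number from compound 1 to compound 2 (0.52 log units; beyond the scatter), and that step concerns hydrogen against acetyl, not acetyl against methylsulfonyl. Among the measured compounds shown here, the data hold no step that swaps one such group for another on this oxygen, so the direction of the change from compound 2 to compound 3 cannot be read from a precedent. A step of about the size seen from compound 1 to compound 2, in either direction, or none beyond the scatter, are all consistent with what is known. Compound 3 is expected to give about 70 nM, within 20 nM to 250 nM. The step of a 1.0-fold higher number from compound 2 to compound 3 (0.02 log units; within the scatter) is thus estimated to stay within the scatter.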

Compound 3, half-maximal inhibitory concentration: 6.4 nM
Compound 3: middle estimate off by 11-fold (1.04 log units), on the high side, and the stated range ends above it.
By their numbers in this assay, from the lowest: compound 3; then compound 2; then compound 1.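

In this assay, within the data shown here, the oxygen on a saturated carbon proves far more sensitive to the group it carries than the first pair of compounds suggested: the change from acetoxy to (methylsulfonyl)oxy gives a 10-fold lower number from compound 2 to compound 3 (1.02 log units; beyond the scatter), a large step where the earlier one, a 3.3-fold lower number from compound 1 to compound 2 (0.52 log units; beyond the scatter), was modest. Set against the hydrogen on this oxygen, methylsulfonyl gives a 34-fold lower number from compound 1 to compound 3 (1.54 log units; beyond the scatter), so both groups lower the number, yet acetyl and methylsulfonyl, each with no hydrogen-bond donor, still stand well apart, which shows that the identity of the group matters and not only the loss of that hydrogen. Nothing measured alongside these values speaks to what lies behind the step.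

The compounds shown leave open whether the gain belongs to sulfonyl groups in general or to methylsulfonyl in particular, a question that an ethylsulfonyl or phenylsulfonyl group on this oxygen would address. They also leave open whether the oxygen itself is needed, as a sulfonamide nitrogen in its place would test on the same shared core.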